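Hydroxy for Dimethylamino on a Benzimidazole-Type Aorta Inhibitor

The compounds below may be only part of what the source reports. "The series", "measured", "known", "first", "only" and "open" are said of these compounds alone.

Measured so far:
compound 1, `COc1cc(-c2nc3cc([N+](=O)[O-])ccc3[nH]2)ccc1O`: 55.2%
compound 2, `CN(C)c1ccc(-c2nc3cc(C(F)(F)F)ccc3[nH]2)cc1`: 30.9%

In a functional assay on aorta (Rattus norvegicus, strain Wistar) for inhibition, with a stated time of 60 min (a higher number here means a larger maximal response, a lower number a smaller maximal response), compound 2 gives 30.9%, the lowest of the two numbers; compound 1 lies well above it, beyond the scatter. Compound 3, `Oc1ccc(-c2nc3cc(C(F)(F)F)ccc3[nH]2)cc1`, is not yet measured. It differs from compound 2 by hydroxy in place of dimethylamino on an aromatic carbon. Because compound 1, which also carries a hydroxy, gives 55.2%, a moderate rise in the largest response is expected for compound 3; an estimated step of a number 14.1 percentage points higher from compound 2 to compound 3 (beyond the scatter) is assumed. Compound 3 is expected to give 45%, within 28% to 62%.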

Compound 3, largest response reached (Emax), in percent of the reference or control that the assay uses: 37%
Compound 3: the middle estimate sits 8 percentage points above what was measured, and the stated range covers the measured number.
By their numbers in this assay, from the lowest: compounds 2 and 3 (each within the scatter of the next); then compound 1.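

In this assay, putting hydroxy in place of dimethylamino on the aromatic carbon para to a large group gives a number 6.1 percentage points higher from compound 2 to compound 3 (within the scatter). This first one-place comparison therefore shows that hydroxy, with its hydrogen-bond donor, and dimethylamino, with none, cannot be told apart at this position. Nothing available explains this closeness. The compounds shown leave open whether a primary amine or a carboxylic acid on this carbon would shift the largest response beyond the scatter. They also leave open whether the same exchange would hold with the trifluoromethyl group replaced by a nitrile.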